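The compounds below may be only part of what the source reports. "The series", "measured", "known", "first", "only" and "open" are said of these compounds alone.

Compound 1 `COc1ccc(Cn2cc(CNC(=O)c3cn(-c4ccccc4)nc3-c3ccc(F)cc3)nn2)cc1` holds the lower of the two numbers recorded in a functional assay on MCF7 cells (Homo sapiens) for antiproliferative activity, read by sulforhodamine B assay, with a stated time of 48 h; on this read-out higher numbers stand for weaker inhibition of growth and lower numbers for stronger inhibition of growth: compound 1 gives 650 nM. Compound 2 `COc1cc(Cn2cc(CNC(=O)c3cn(-c4ccccc4)nc3-c3ccc(F)cc3)nn2)cc(OC)c1OC` gives 4300 nM in this assay; that step, a 6.6-fold higher number from compound 1 to compound 2 (0.82 log units; beyond the scatter), is the only one measured, and it alters a different part of the molecule. Compound 3 `COc1ccc(Cn2cc(CNC(=O)c3cn(-c4ccccc4)nc3-c3ccc(Cl)cc3)nn2)cc1` differs from compound 1 by chloro in place of fluoro on an aromatic carbon. Going by the values given here, no measured step bears on this change, so nothing beyond the usual scatter is expected in this assay; for compound 3 the step is estimated as no change at the digits printed from compound 1 to compound 3 (within the scatter). Compound 3 is therefore expected at 650 nM, with a range from 250 nM to 1700 nM.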

Compound 3, concentration for 50% growth inhibition: 8000 nM
Beside the measured number, compound 3's estimate is 12-fold (1.09 log units) below it; measured number outside the range, above it.
By their numbers in this assay, from the lowest: compound 1; then compounds 2 and 3 (each within the scatter of the next).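

Until now only the methoxyphenyl end of the molecule had been changed; this result shows that the far end also matters. Going from 4-fluorophenyl to 4-chlorophenyl swaps a single atom, yet in this assay it gives a 12-fold higher number from compound 1 to compound 3 (1.09 log units; beyond the scatter), a clear loss of growth inhibition, so this aromatic carbon does not tolerate every halogen. Nothing available explains this loss. Still open, from the compounds shown here alone, is how bromo, methyl or an amine would fare at this place, and whether a bare phenyl ring would hold the activity of compound 1.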